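The compounds below may be only part of what the source reports. "The series", "measured", "known", "first", "only" and "open" are said of these compounds alone.

Measured so far in a functional assay on HeLa cells (Homo sapiens) for antiproliferative activity, read by MTT assay, with a stated time of 24 h; on this read-out higher numbers stand for weaker inhibition and lower numbers for stronger inhibition:
Compound 1, `Cc1ccc(-c2nn(-c3ccccc3)cc2-c2nc3ccccc3n2S(=O)(=O)c2ccc(C)cc2)cc1`: 480 nM.
Compound 2, `Cc1ccc(-c2nn(-c3ccccc3)cc2-c2nc3ccccc3n2S(=O)(=O)c2ccc(Cl)cc2)cc1`: 4060 nM.
Compound 3, `Cc1ccc(-c2nn(-c3ccccc3)cc2-c2nc3ccccc3n2S(=O)(=O)c2ccc(C(F)(F)F)cc2)cc1`: 1520 nM.

Compound 3 gives the second highest of these three numbers. Its nearest neighbour is compound 2, reached by a 2.7-fold lower number from compound 2 to compound 3 (0.43 log units; beyond the scatter), and its furthest is compound 1, reached by a 3.2-fold higher number from compound 1 to compound 3 (0.50 log units; beyond the scatter).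

Compound 4, `O=S(=O)(c1ccc(C(F)(F)F)cc1)n1c(-c2cn(-c3ccccc3)nc2-c2ccc(C(F)(F)F)cc2)nc2ccccc21`, differs from compound 3 by trifluoromethyl in place of methyl on an aromatic carbon. Among the measured compounds shown here, the one measured step with the same change, methyl to trifluoromethyl on an aromatic carbon, is a 3.2-fold higher number from compound 1 to compound 3 (0.50 log units; beyond the scatter), although there the change sat on the other six-membered ring. Carrying that over, a modest rise in the number is expected for compound 4, about a 2.3-fold higher number from compound 3 to compound 4 (0.36 log units; beyond the scatter), in this assay. Compound 4 is therefore estimated at 3500 nM, within a range of 1200 nM to 10000 nM.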

Compound 4, half-maximal inhibitory concentration: 970 nM
The estimate for compound 4 lay 3.6-fold (0.56 log units) above the measured number; measured number below the stated range.
By their numbers in this assay, from the lowest: compound 1; then compounds 4 and 3 (each within the scatter of the next); then compound 2.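

In this assay, 4-(trifluoromethyl)phenyl in place of 4-methylphenyl gives a 1.6-fold lower number from compound 3 to compound 4 (0.20 log units; within the scatter) and so cannot be told apart from repeat measurement at this position. The same swap on the other six-membered ring gave a 3.2-fold higher number from compound 1 to compound 3 (0.50 log units; beyond the scatter) and could be told apart, so in these two pairs the outcome depends on where the swap sits. No measurement offers a reason for this contrast. Still open, on these data alone, is how an amine or a carboxylic acid would behave at this place on the ring. Also open, as far as these compounds go, is whether this swap reads the same with the methyl of compound 1 kept on the other ring.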